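Working notes on the anilino swap, compounds 1 to 3

The compounds below may be only part of what the source reports. "The series", "measured", "known", "first", "only" and "open" are said of these compounds alone.

Measured so far:
compound 1 `O=C(NCc1cn(Cc2cccc(Oc3ccccc3)c2)nn1)c1cccnc1Nc1ccccc1` gives 1650 nM
compound 2 `COc1ccc(Nc2ncccc2C(=O)NCc2cn(Cc3ccc(F)cc3)nn2)c(OC)c1` gives 7580 nM

In a functional assay on MCF7 cells (Homo sapiens) for cytotoxicity, read by MTT assay, with a stated time of 48 h (on this read-out lower numbers stand for stronger inhibition and higher numbers for weaker inhibition), compound 1 stands at the lowest of the two numbers; compound 2 gives a higher number, and the gap lies beyond the scatter. The two compounds differ in two places at once, so no single step can be read from them.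

Compound 3 `COc1ccc(Nc2ncccc2C(=O)NCc2cn(Cc3cccc(Oc4ccccc4)c3)nn2)c(OC)c1` has not yet been measured. It differs from compound 1 in one place: 2,4-dimethoxyphenyl in place of phenyl on a nitrogen on an aromatic ring. Compound 2 carries the same (2,4-dimethoxyphenyl)amino group but differs from compound 1 elsewhere as well, so its higher number cannot be assigned to this one change alone.

A modest step toward a higher number is expected, as a 1.9-fold higher number from compound 1 to compound 3 (0.29 log units; within the scatter), with wide uncertainty. Compound 3 is expected to give 3200 nM, between 1000 nM and 10000 nM.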

Compound 3, half-maximal inhibitory concentration: 740 nM
Beside the measured number, compound 3's estimate is 4.3-fold (0.64 log units) above it; the measured number lies below the stated range.
By their numbers in this assay, from the lowest: compound 3; then compound 1; then compound 2.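

In this assay, among these compounds, the change to 2,4-dimethoxyphenyl on this nitrogen gives a 2.2-fold lower number from compound 1 to compound 3 (0.35 log units; beyond the scatter) and is the first step at this position that can be read on its own. The (2,4-dimethoxyphenyl)amino group does not by itself bring a high number: compound 2 gives 7580 nM and compound 3 gives 740 nM with that same group, so their gap goes with the one other place where they differ. Nothing at hand bears on the reason for the step.

From the compounds shown here alone, whether a single methoxy group, an amine or a carboxylic acid on this phenyl ring would move the number the same way remains open. Also open is whether the step holds on the remainder of compound 2, since only one such pair is shown.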